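The compounds below may be only part of what the source reports. "The series", "measured", "known", "first", "only" and "open" are said of these compounds alone.

Measured compounds:
- compound 1 `Cc1ccc2nc(Nc3nc(Nc4ccc(S(N)(=O)=O)cc4)ncc3C)sc2c1` gives 9080 nM
- compound 2 `NS(=O)(=O)c1ccc(Nc2nccc(Nc3nc4ccc(F)cc4s3)n2)cc1` gives 1800 nM

Both compounds were run in a functional assay on MDA-MB-231 cells (Homo sapiens) for antiproliferative activity, read by MTT assay, with a stated time of 48 h; on this read-out higher numbers stand for weaker inhibition and lower numbers for stronger inhibition. Of the two numbers, compound 2 has the lower one, and the gap to compound 1 lies beyond the scatter. Compound 1 and compound 2 differ in more than one place, so their two values can only be set side by side; no single change can be read from them.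

The next compound is compound 3 `Cc1cnc(Nc2ccc(S(N)(=O)=O)cc2)nc1Nc1nc2ccc(F)cc2s1`, to be measured in this assay. It differs from compound 2 by methyl in place of hydrogen on an aromatic carbon. Among the compounds with values here, no pair of measured compounds shows this change on its own. Within the data shown here, the only hint is that compound 1, which also carries this methyl on its core, gives 9080 nM, a weaker value than compound 2, but compound 1 also differs elsewhere, so the hint is loose. A modest step toward weaker inhibition, or none beyond the scatter, is expected a 1.9-fold higher number from compound 2 to compound 3 (0.29 log units; within the scatter). Compound 3 is estimated at 3500 nM, within a range of 1200 nM to 10000 nM.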

Compound 3, half-maximal inhibitory concentration: 7580 nM
Estimate against measurement, compound 3: 2.2-fold (0.34 log units) below, within the range that was stated.
By their numbers in this assay, from the lowest: compound 2; then compounds 3 and 1 (each within the scatter of the next).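

In this assay, within the data shown here, methyl in place of hydrogen on an aromatic carbon of the six-membered aromatic ring with 2 nitrogen gives a 4.2-fold higher number from compound 2 to compound 3 (0.62 log units; beyond the scatter), the first reading of this single change, and it is a loss beyond the scatter. Fluoro in place of methyl on an aromatic carbon gives a 1.2-fold lower number from compound 1 to compound 3 (0.08 log units; within the scatter), which lies within the scatter, so across these three compounds the gap between compound 1 and compound 2, which could not be read earlier, sits with the methyl on the core and not with the fluoro-for-methyl change. Nothing on hand accounts for the loss that comes with this methyl.

Only hydrogen and methyl are shown on this carbon, so how an ethyl group, a chloro group or an amine there would read in this assay stays open. From the compounds shown here alone, the fluoro-for-methyl step is read only with the methyl on the core, so whether it stays within the scatter with hydrogen on that carbon also stays open.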